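Methoxy for Fluoro on the Styryl Ring of Compound 3

This account rests on a few compounds, and the source may have more. Where it says the series, first, only, none or still open, it means among the compounds named here.

Measured so far:
Compound 1, `COc1ccc(-c2cc3cc(-c4ccccc4)cc(C(C)=O)c3[nH]2)cc1`: in a functional assay on MCF7 cells (Homo sapiens) for cytotoxicity, read by MTT assay, with a stated time of 2 days, tested at 1 uM (a higher number here means a weaker effect of the compound at the concentration tested, a lower number a stronger effect), compound 1 gives 78.1%.
Compound 2, `COc1ccc(-c2cc(C(C)=O)c3[nH]c(-c4ccc(OC)cc4)cc3c2)cc1`: in this assay compound 2 gives 62.6%.
Compound 3, `CC(=O)c1cc(/C=C/c2ccc(F)cc2)cc2cc(-c3ccc(F)cc3)[nH]c12`: in this assay compound 3 gives 82%.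

Compound 3 sits at the upper end of these three numbers. Compound 1 cannot be told apart from it, the gap being within the usual scatter, whereas compound 2 lies beyond the scatter, lower. Compound 4, `COc1ccc(-c2cc3cc(/C=C/c4ccc(F)cc4)cc(C(C)=O)c3[nH]2)cc1`, has not yet been measured. It differs from compound 3 in one place: methoxy in place of fluoro on an aromatic carbon, the same difference cut one bond further out reading 4-fluorophenyl to 4-methoxyphenyl.

Within the data shown here, no measured pair repeats exactly this exchange. Among the measured compounds shown here, the only step with a methoxy group entering is a number 15.5 percentage points lower from compound 1 to compound 2 (beyond the scatter), a modest lowering beyond the scatter, but there methoxy replaced hydrogen, not fluoro, and on a different ring. Taken as a loose guide it points to a small drop at most. The step of a number 10 percentage points lower from compound 3 to compound 4 (within the scatter) is therefore expected to be modest and downward, perhaps within the scatter. Compound 4 is estimated to give 72% in this assay, with a range from 58% to 86%.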

Compound 4, a percentage reported as activity, at one concentration (the size of the read-out at that concentration, not a potency): 97.3%
Beside the measured number, compound 4's estimate is 25.3 percentage points below it; measured number above the stated range.
By their numbers in this assay, from the lowest: compound 2; then compounds 1 and 3 (each within the scatter of the next); then compound 4.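

In this assay methoxy in place of fluoro on this aromatic carbon raises the number (a number 15.3 percentage points higher from compound 3 to compound 4 (beyond the scatter)), which means a weaker effect at the concentration tested, whereas methoxy in place of hydrogen on an aromatic carbon went the other way (a number 15.5 percentage points lower from compound 1 to compound 2 (beyond the scatter)), so methoxy entering does not move the number in one direction across these compounds. The two further steps place compound 4 as the weakest of the four, with 2-(4-fluorophenyl)ethenyl in place of 4-methoxyphenyl (a number 34.7 percentage points higher from compound 2 to compound 4 (beyond the scatter)) and in place of phenyl (a number 19.2 percentage points higher from compound 1 to compound 4 (beyond the scatter)). No measurement shown here accounts for this rise.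

The compounds shown leave open how a hydroxyl or an amine on this same carbon would read. They also leave open whether the rise would persist at other concentrations.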